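From 4-fluorophenyl to 4-chlorophenyl: notes on the series

The source may report more compounds than this note shows. Statements on the series, on what has been measured and on what is new or still open speak of the compounds shown alone.

In an ADME assay on THP-1 cells (Homo sapiens) for cytotoxicity, read by MTT assay (on this read-out lower numbers stand for stronger inhibition and higher numbers for weaker inhibition), compound 1 `ClC(Cl)(Cl)c1nc(-c2ccccc2)c2ccccc2n1` gives 125000 nM. Compound 2 `Fc1ccc(-c2nc(C(Cl)(Cl)Cl)nc3ccccc23)cc1` gives 125000 nM, which leaves it level with compound 1 at the digits shown and makes compound 1 its nearest neighbour. Compound 3 `COc1cc(-c2nc(C(Cl)(Cl)Cl)nc3ccccc23)cc(OC)c1OC` gives > 250000 nM, which is a limit of the assay and not a number. Going by the values given here, no single-place step joins compound 3 to the others, so it does not enter the reasoning below.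

Compound 4 `Clc1ccc(-c2nc(C(Cl)(Cl)Cl)nc3ccccc23)cc1` has not yet been measured. It differs from compound 2 in one place: chloro in place of fluoro on an aromatic carbon. In words, this is chloro in place of fluoro on an aromatic carbon, para to a large group.

Among the compounds with values here, one measured step bears on this change, the replacement of hydrogen by fluoro on an aromatic carbon: no change at the digits printed from compound 1 to compound 2 (within the scatter). It is the only measure of how substitution at this place moves the read-out, and chloro itself has not been tested here. On that basis, no step beyond the scatter is expected in this assay, and no direction is favoured.

The estimated step of a 1.1-fold lower number from compound 2 to compound 4 (0.06 log units; within the scatter) is expected to stay within the scatter. The expected value for compound 4 is 110000 nM, with an estimated range of 50000 nM to 230000 nM.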

Compound 4, half-maximal inhibitory concentration: 73200 nM
Compound 4: middle estimate off by 1.5-fold (0.18 log units), on the high side; low and high end bracket the measured number.
By their numbers in this assay, from the lowest: compounds 4, 1 and 2 (each within the scatter of the next). At a limit, above all of these: compound 3.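

In this assay the exchange of one halogen for another at this place now has a reading of its own, with a 1.7-fold lower number from compound 2 to compound 4 (0.23 log units; within the scatter) as the measured step for 4-fluorophenyl to 4-chlorophenyl. Set against the unsubstituted phenyl of compound 1, the chloro group gives a 1.7-fold lower number from compound 1 to compound 4 (0.23 log units; within the scatter) as its step, which adds a second substituent to the single fluoro step available before. Hydrogen, fluoro and chloro on this aromatic carbon therefore all give values within the scatter of one another, so the read-out has not yet separated these three atoms at this place, a statement that holds only for compound 1, compound 2 and compound 4.

On these data alone, whether an amine, a carboxylic acid or a longer alkyl chain at this place would give a step beyond the scatter remains open, as does whether the same holds with the trichloromethyl group of the shared core exchanged for another group. Nothing among the measurements shown gives a reason for the values of these three compounds.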